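The source may report more compounds than this note shows. Statements on the series, on what has been measured and on what is new or still open speak of the compounds shown alone.

Measured so far: compound 1 `COC(=O)c1sc2ncnc(Nc3cc(C)cn(C)c3=O)c2c1C` gives > 10000 nM in an assay on isolated protein for inhibition of MAP kinase-interacting serine/threonine-protein kinase 2 (Homo sapiens), read by ADP-Glo, with a stated time of 10 min; on this read-out higher numbers stand for weaker inhibition and lower numbers for stronger inhibition; compound 2 `CCNC(=O)c1sc2ncnc(Nc3cc(C)cn(C)c3=O)c2c1C` gives 5990 nM.

For compound 1 only a limit of the assay is known, (the limit of > 10000 nM in this assay, at which 1 of the 2 values shown sits), so its own number is not fixed. Compound 3 `COCCCNC(=O)c1sc2ncnc(Nc3cc(C)cn(C)c3=O)c2c1C` differs from compound 1 by (3-methoxypropyl)amino in place of methoxy on a carbonyl carbon. Among the measured compounds shown here, the one measured step that bears on this is an at least 1.6-fold lower number from compound 1 to compound 2 (0.22 log units; that floor lies within the scatter), where an amide likewise replaced the methoxy on the carbonyl carbon; that step did not clear the scatter. A step of similar size and direction, an at least 2.0-fold lower number from compound 1 to compound 3 (0.30 log units; that floor lies within the scatter), is therefore expected here. Compound 3 is estimated at 5000 nM, within 2000 nM to 12000 nM.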

Compound 3, inhibition constant: 2630 nM
Compound 3: the middle estimate sits 1.9-fold (0.28 log units) above what was measured; the measured number falls inside the stated range.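

Among the compounds shown here, compound 3 gives the first change at this carbonyl carbon that clears the scatter, with an at least 3.8-fold lower number from compound 1 to compound 3 (0.58 log units; beyond the scatter). Compound 1 has only a limit, so that step is a floor: the limit of > 10000 nM in this assay, at which 1 of the 3 values shown sits. The amide substituent also matters, since extending the chain gives a 2.3-fold lower number from compound 2 to compound 3 (0.36 log units; beyond the scatter), so the amide alone does not account for the whole step.

The compounds shown leave open whether the length of the chain or its oxygen carries this step. A plain alkyl chain of the same length, or a chain ending in an amine or a carboxylic acid, would bear on that question.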